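The source may hold more compounds than are shown below. What is called first, only, known or untested is meant among the compounds shown, and "the series" means these compounds.

Compound 3, with structure `N#Cc1ccc(CSc2ncnc3c2ncn3[C@@H]2O[C@H](CO)[C@@H](O)[C@H]2O)cc1`, gives the lowest number of the three measured compounds in an assay on isolated protein for inhibition of Equilibrative nucleoside transporter 1 (Homo sapiens) (a lower number here means a stronger inhibitor, a higher number a weaker inhibitor), namely 4.57 nM. Compound 2 `OC[C@H]1O[C@@H](n2cnc3c(SCc4ccc(Br)cc4)ncnc32)[C@H](O)[C@@H]1O` gives 11.5 nM, and compound 1 `OC[C@H]1O[C@@H](n2cnc3c(SCc4ccccc4Cl)ncnc32)[C@H](O)[C@@H]1O` gives 117 nM. The measured steps were a 10-fold lower number from compound 1 to compound 2 (1.01 log units; beyond the scatter), a 26-fold lower number from compound 1 to compound 3 (1.41 log units; beyond the scatter) and a 2.5-fold lower number from compound 2 to compound 3 (0.40 log units; beyond the scatter), so swapping the group on the phenyl ring changes the number strongly. Compound 4 `O=[N+]([O-])c1cccc(CSc2ncnc3c2ncn3[C@@H]2O[C@H](CO)[C@@H](O)[C@H]2O)c1` differs from compound 3 by 3-nitrophenyl in place of 4-cyanophenyl on a saturated chain carbon bound to a sulfur. For the measured compounds named here, no measured step covers a 3-nitrophenyl, but since the two large steps show that moving or exchanging the phenyl substituent shifts the number well beyond the scatter, a modest weakening is expected, giving a 2.6-fold higher number from compound 3 to compound 4 (0.42 log units; beyond the scatter) in this assay. For compound 4 the estimate in this assay is 12 nM, with a range from 4 nM to 40 nM.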

Compound 4, inhibition constant: 1.78 nM
Estimate against measurement, compound 4: 6.7-fold (0.83 log units) above, and the stated range ends above it.
By their numbers in this assay, from the lowest: compound 4; then compound 3; then compound 2; then compound 1.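

In this assay the 3-nitrophenyl group gives a 2.6-fold lower number from compound 3 to compound 4 (0.41 log units; beyond the scatter) and a 6.5-fold lower number from compound 2 to compound 4 (0.81 log units; beyond the scatter) and a 66-fold lower number from compound 1 to compound 4 (1.82 log units; beyond the scatter) and so compound 4 is the strongest inhibitor of the four. For the compounds shown here, the place on the saturated chain carbon bound to a sulfur therefore allows a lower number than 4-cyanophenyl, the best group among the earlier compounds. No measurement here explains this gain. Going by these compounds, compound 3 and compound 4 differ in both the ring substituent and its ring position, so the contribution of each stays open. On these data alone, how an amine or a carboxylic acid on the phenyl ring would behave also stays open.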